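A few compounds are considered here, and "the series" means these few. Any claim that something is new, unique, unknown or untested is made for them only; others in the source may bear on it.

Measured so far in an ADME assay on L02 cells (Homo sapiens) for antiproliferative activity, read by MTT assay, with a stated time of 48 h; on this read-out lower numbers stand for stronger inhibition and higher numbers for weaker inhibition:
compound 1, `COc1ccccc1-n1nncc1CN1C(=O)C2(C(C#N)=C(N)Oc3c2c2nc4ccccc4nc2c2ccccc32)c2ccccc21`, gives > 50000 nM
compound 2, `CCc1ccccc1-n1nncc1CN1C(=O)C2(C(C#N)=C(N)Oc3c(N)cc4nc5ccccc5nc4c32)c2ccccc21`, gives 22900 nM
These are the only two results so far in this assay.

For compound 1 the reported result > 50000 nM is a limit of this assay, not a number. That is the situation described by the limit of > 50000 nM in this assay, at which 1 of the 2 values shown sits. For the measured compounds named here, compound 2 is therefore the only compound here with an actual number in this assay, and compound 2 gives 22900 nM. Going by the values given here, no step between two measured compounds exists in these data, so there is no measured change to build on.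

Compound 3 is `Cc1ccc(-n2nncc2CN2C(=O)C3(C(C#N)=C(N)Oc4c(N)cc5nc6ccccc6nc5c43)c3ccccc32)cc1Cl`. It differs from compound 2 in one place: 3-chloro-4-methylphenyl in place of 2-ethylphenyl on an aromatic nitrogen. Both the leaving group and the entering group are six-membered aromatic rings of carbon only, without hydrogen-bond donors or acceptors, sitting on the same aromatic nitrogen of the five-membered aromatic ring with three nitrogen.

Given that only one number is available and the change swaps one such ring for another, the step in this assay is expected to be small, with no clear direction, and not beyond the usual scatter. Compound 3 is expected to give about 25000 nM in this assay, within a range of 8000 nM to 60000 nM. The expected step of a 1.1-fold higher number from compound 2 to compound 3 (0.04 log units; within the scatter) thus stays inside the scatter.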

Compound 3, half-maximal inhibitory concentration: > 50000 nM
Compound 3 ended at the assay's limit; the forecaster's own chance of this, stated with the estimate: 30%; at least 2.0-fold (0.30 log units) between middle value and limit.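

In this assay, the group on the aromatic nitrogen of the five-membered ring proves able to shift the read-out: putting 3-chloro-4-methylphenyl in place of 2-ethylphenyl gives an at least 2.1-fold higher number from compound 2 to compound 3 (0.33 log units; beyond the scatter). Both groups are six-membered aromatic rings of carbon only, with the same number of heavy atoms and no hydrogen-bond donors or acceptors, so these counts alone do not settle the result at this position. Compound 3 gives > 50000 nM, which is a limit of the assay and not a number, so the true size of the step remains unknown, and this limit now holds most of the results: the limit of > 50000 nM in this assay, at which 2 of the 3 values shown sit.

On these data alone, this single swap changes several features at once, so it remains open whether the result follows from removing the 2-ethyl group, adding the chlorine, adding the methyl, or the places these groups occupy on the ring. Comparing compound 2 with an otherwise identical compound carrying plain phenyl, 2-methylphenyl or 3-chlorophenyl would begin to separate these possibilities, and an amine on the ring would test a different kind of group.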